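The compounds below may be only part of what the source reports. "The series", "measured", "known", "first", "only" and "open" are said of these compounds alone.

Values measured in a functional assay on MIA PaCa-2 cells (Homo sapiens) for antiproliferative activity; a lower number here means that less compound is needed, a higher number that more compound is needed for the effect:

- compound 1 `C#CCCNC(=O)c1cccc2c1cc(C)n2-c1nc2c(c(NCc3ccccc3)n1)CCCC2`: 1410 nM
- compound 2 `CCCNC(=O)c1cccc2c1cc(C)n2-c1nc2c(c(NCc3ccccc3)n1)CCCC2`: 608 nM
- compound 3 `C#CC(=O)Nc1cccc2c1cc(C)n2-c1nc2c(c(NCc3ccccc3)n1)CCCC2`: 131 nM

Compound 3, at 131 nM, has the lowest number of the three. The other two lie beyond the scatter from it, as shown by a 4.6-fold lower number from compound 2 to compound 3 (0.67 log units; beyond the scatter) and by an 11-fold lower number from compound 1 to compound 3 (1.03 log units; beyond the scatter).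

Compound 4 `CCCC#CC(=O)Nc1cccc2c1cc(C)n2-c1nc2c(c(NCc3ccccc3)n1)CCCC2` departs from compound 3 in one place: propyl in place of hydrogen on a triple-bonded carbon. Propyl takes the place of hydrogen on a triple-bonded carbon, so that ethynyl becomes pent-1-yn-1-yl.

Among the measured compounds shown here, no measured step makes this change, so the evidence is indirect. The closest is a 2.3-fold lower number from compound 1 to compound 2 (0.37 log units; beyond the scatter), a modest step in which methyl replaces ethynyl on a saturated chain. The large 11-fold lower number from compound 1 to compound 3 (1.03 log units; beyond the scatter) also leads from a group of more heavy atoms to one of fewer. Both steps run from compound 1 to a lower number, which suggests that the larger group in compound 4 will carry a higher number. For the measured compounds named here, with only three compounds, and none altered at this carbon, that reading is weak.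

A modest to large rise is therefore expected, an estimated 4.2-fold higher number from compound 3 to compound 4 (0.62 log units; beyond the scatter). The expected value for compound 4 is 550 nM, with an estimated range of 170 nM to 2000 nM.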

Compound 4, half-maximal effective concentration: 1570 nM
The estimate for compound 4 lay 2.9-fold (0.46 log units) below the measured number, and the stated range covers the measured number.
By their numbers in this assay, from the lowest: compound 3; then compound 2; then compounds 1 and 4 (each within the scatter of the next).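

In this assay, the triple-bonded carbon that carries hydrogen in compound 3 turns out not to tolerate every replacement: propyl in place of that hydrogen, turning ethynyl into pent-1-yn-1-yl, is a large step upward (a 12-fold higher number from compound 3 to compound 4 (1.08 log units; beyond the scatter)). The low number of compound 3 therefore does not carry over to the longer alkyne on the same aromatic carbon, and the group in compound 4 also gives up the position held by the propylcarbamoyl group (a 2.6-fold higher number from compound 2 to compound 4 (0.41 log units; beyond the scatter)) and cannot be told apart from the group in compound 1 (a 1.1-fold higher number from compound 1 to compound 4 (0.05 log units; within the scatter)). Nothing measured on these compounds accounts for the rise.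

The compounds shown leave open whether a single methyl or an ethyl on that triple-bonded carbon would already bring the same rise, or whether the number climbs only as the chain reaches propyl. They also leave open how a dimethylaminomethyl or hydroxymethyl group on that carbon, or a chain longer than propyl, would compare with hydrogen in this assay.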